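Swapping a halogen on the aniline of compound 3

The source may hold more compounds than are shown below. What is called first, only, known or untested is meant among the compounds shown, and "the series" means these compounds.

Compound 1 `COc1ncc(-c2ccc3ncnc(Nc4ccc(OCCO)cc4)c3c2)cc1NS(=O)(=O)c1ccc(F)cc1F`, in a functional assay on HCT-116 cells (Homo sapiens) for antiproliferative activity, read by sulforhodamine B assay, with a stated time of 72 h (a higher number here means a weaker inhibitor, a lower number a stronger inhibitor), compound 1 gives 1060 nM.
Compound 2 `COc1ncc(-c2ccc3ncnc(Nc4ccc(OCCCO)nc4)c3c2)cc1NS(=O)(=O)c1ccc(F)cc1F`, in this assay compound 2 gives 3680 nM.
Compound 3 `COc1ncc(-c2ccc3ncnc(Nc4ccc(OCCO)c(F)c4)c3c2)cc1NS(=O)(=O)c1ccc(F)cc1F`, in this assay compound 3 gives 9160 nM.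

Compound 3 has the highest number of the three in this assay: it stands a 2.5-fold higher number from compound 2 to compound 3 (0.40 log units; beyond the scatter) and an 8.6-fold higher number from compound 1 to compound 3 (0.94 log units; beyond the scatter). Compound 4 `COc1ncc(-c2ccc3ncnc(Nc4ccc(OCCO)c(Cl)c4)c3c2)cc1NS(=O)(=O)c1ccc(F)cc1F` differs from compound 3 by a single substitution, (chloro in place of fluoro on an aromatic carbon). Among the measured compounds shown here, no measured pair shows a chloro replacing a fluoro, so the closest guide is the step that introduced the fluoro itself, an 8.6-fold higher number from compound 1 to compound 3 (0.94 log units; beyond the scatter), which shows that a substituent at this position weighs on the number, while the step of a 3.5-fold higher number from compound 1 to compound 2 (0.54 log units; beyond the scatter) concerns a different part of the aniline and bears on it only indirectly. A halogen is already present in compound 3, and the change to chloro keeps its count of heavy atoms, donors and acceptors unchanged, so a step within or only slightly beyond the scatter is expected, if anything towards a higher number. Compound 4 is therefore estimated at 11000 nM in this assay, with a range of 3500 nM to 35000 nM, that is a step of a 1.2-fold higher number from compound 3 to compound 4 (0.08 log units; within the scatter).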

Compound 4, half-maximal inhibitory concentration: 7320 nM
Beside the measured number, compound 4's estimate is 1.5-fold (0.18 log units) above it; the measured number falls inside the stated range.
By their numbers in this assay, from the lowest: compound 1; then compounds 2, 4 and 3 (each within the scatter of the next, the first and the last beyond it).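

In this assay, the exchange of one halogen for the other at this position gives a 1.3-fold lower number from compound 3 to compound 4 (0.10 log units; within the scatter), while chloro in place of hydrogen gives a 6.9-fold higher number from compound 1 to compound 4 (0.84 log units; beyond the scatter), so the rise first seen with fluoro is not confined to fluoro and also appears with chloro. Set against compound 2, the 3-chloro-4-(2-hydroxyethoxy)phenyl group in place of 6-(3-hydroxypropoxy)pyridin-3-yl gives a 2.0-fold higher number from compound 2 to compound 4 (0.30 log units; within the scatter), which leaves these two compounds unseparated in this assay. Nothing available explains why either halogen goes with a higher number than the hydrogen of compound 1.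

The compounds shown leave open whether bromo, methyl, methoxy or an amine on this aromatic carbon would stay with the halogens or come closer to the hydrogen of compound 1. They also leave open whether a longer chain or a carboxylic acid in place of the 2-hydroxyethoxy group would alter the step seen with chloro, since that group is the same in compound 1, compound 3 and compound 4.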